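From Propylamino to Pentylsulfanyl on a Shared Core

The source may hold more compounds than are shown below. What is called first, only, known or untested is meant among the compounds shown, and "the series" means these compounds.

Of the compounds shown here, three built on one core have been tested in a functional assay on the whole organism for activation, with Mus musculus as the target; on this read-out higher numbers stand for an effect only at larger amounts of compound and lower numbers for an effect already at smaller amounts. Compound 1 `CCc1nc(N)c2nc(O)n(Cc3ccccc3)c2n1` carries an ethyl group on an aromatic carbon and gives 3 mg/kg. Compound 2 `CSc1nc(N)c2nc(O)n(Cc3ccccc3)c2n1` carries methylsulfanyl in that place and gives 0.1 mg/kg. Compound 3 `CCCNc1nc(N)c2nc(O)n(Cc3ccccc3)c2n1` carries propylamino and gives 1 mg/kg. Among these three numbers compound 3 stands second highest: the step of a 3.0-fold lower number from compound 1 to compound 3 (0.48 log units; beyond the scatter) separates it from compound 1, and the step of a 10-fold higher number from compound 2 to compound 3 (1.00 log units; beyond the scatter) separates it from compound 2.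

Compound 4 `CCCCCSc1nc(N)c2nc(O)n(Cc3ccccc3)c2n1` differs from compound 3 in a single place: pentylsulfanyl in place of propylamino on an aromatic carbon. The measured step that bears most directly on this change is a 10-fold higher number from compound 2 to compound 3 (1.00 log units; beyond the scatter), where a sulfanyl group gave way to propylamino; the reverse exchange would be expected to lower the number again. The step of a 30-fold lower number from compound 1 to compound 2 (1.48 log units; beyond the scatter) adds that methylsulfanyl gave the lowest number of the set. Within the data shown here, what enters here, however, is a pentyl chain rather than methyl, and no measured pair shows how chain length on the sulfur affects the read-out. For compound 4 the step is therefore expected to be a 3.3-fold lower number from compound 3 to compound 4 (0.52 log units; beyond the scatter), held to a wide range. The estimate for compound 4 in this assay is 0.3 mg/kg, between 0.05 mg/kg and 3 mg/kg.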

Compound 4, minimum effective dose: 1 mg/kg
Compound 4: middle estimate off by 3.3-fold (0.52 log units), on the low side; measured number inside the range.
By their numbers in this assay, from the lowest: compound 2; then compounds 3 and 4 (each within the scatter of the next); then compound 1.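

In this assay the exchange of propylamino for pentylsulfanyl on the aromatic carbon between two ring nitrogen atoms gives no change at the digits printed from compound 3 to compound 4 (within the scatter) and so does not bring back the low number of compound 2, which means that sulfur at this place does not carry that number on its own. The pair of sulfanyl compounds supplies what the earlier set lacked, a measured effect of the chain on sulfur: butyl in place of hydrogen on the saturated chain carbon gives a 10-fold higher number from compound 2 to compound 4 (1.00 log units; beyond the scatter), so at this place the methylsulfanyl group and the pentylsulfanyl group are not interchangeable. Compound 4 nevertheless keeps some of the gain over the ethyl group, with a 3.0-fold lower number from compound 1 to compound 4 (0.48 log units; beyond the scatter), and no measurement at hand accounts for any of these steps.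

With only methylsulfanyl and pentylsulfanyl on sulfur, the compounds shown leave open how the number moves across the chains in between, such as ethylsulfanyl or propylsulfanyl, and whether it changes steadily or abruptly. They also leave open how propylsulfanyl would compare with propylamino, a pair that would set sulfur against nitrogen with the chain held the same.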